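The source may report more compounds than this note shows. Statements on the series, on what has been measured and on what is new or still open speak of the compounds shown alone.

In a set of three compounds sharing one core and a 3,4,5-trimethoxyphenyl group on the ring nitrogen, the group on the saturated ring carbon is varied. Compound 1 `COc1cc(N2C(N)=C(C#N)C(c3c(OC)ccc4ccccc34)C3=C2CC(C)(C)CC3=O)cc(OC)c1OC` carries a 2-methoxynaphthalen-1-yl group there; in a functional assay on Ehrlich cells (Mus musculus) for cytotoxicity, tested at 100 ug/mL (a higher number here means a stronger effect of the compound at the concentration tested, a lower number a weaker effect), compound 1 gives 30%. Compound 2 `COc1cc(N2C(N)=C(C#N)C(c3ccccc3O)C3=C2CC(C)(C)CC3=O)cc(OC)c1OC`, with a 2-hydroxyphenyl group at that position, gives 10% in this assay, a step of a number 20 percentage points lower from compound 1 to compound 2 (beyond the scatter). Compound 3 `COc1cc(N2C(N)=C(C#N)C(c3cccc([N+](=O)[O-])c3)C3=C2CC(C)(C)CC3=O)cc(OC)c1OC` bears a 3-nitrophenyl group; in this assay compound 3 gives 30%. That is no change at the digits printed from compound 1 to compound 3 (within the scatter), so compound 3 stands level with compound 1, while against compound 2 the step is a number 20 percentage points higher from compound 2 to compound 3 (beyond the scatter).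

Compound 4 `COc1cc(N2C(N)=C(C#N)C(c3cccs3)C3=C2CC(C)(C)CC3=O)cc(OC)c1OC` differs from compound 3 only in this way: thiophen-2-yl in place of 3-nitrophenyl on a saturated ring carbon. All three measured steps change the same saturated ring carbon, and their sizes ranged from no change beyond the scatter to a modest shift in either direction; none involved a thiophen-2-yl group, so the direction for compound 4 is uncertain. The step of a number 5 percentage points lower from compound 3 to compound 4 (within the scatter) is therefore expected to be small, at most modest. Compound 4 is expected to give 25% in this assay, with a likely range from 10% to 40%.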

Compound 4, a percentage reported as activity, at one concentration (the size of the read-out at that concentration, not a potency): 20%
Estimate against measurement, compound 4: 5 percentage points above; the range from low to high includes it.
By their numbers in this assay, from the lowest: compounds 2, 4, 1 and 3 (each within the scatter of the next, the first and the last beyond it).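

The step of a number 10 percentage points lower from compound 3 to compound 4 (within the scatter) shows that in this assay a five-membered aromatic ring with one hetero atom can take the place of 3-nitrophenyl on this saturated ring carbon, with 5 heavy atoms entering for 9 leaving and no shift beyond the scatter. The other two steps, a number 10 percentage points higher from compound 2 to compound 4 (within the scatter) and a number 10 percentage points lower from compound 1 to compound 4 (within the scatter) also stay within it, so compound 4 falls on neither side of the one gap among these groups that exceeds the scatter, the gap between compound 2 and compound 3. Nothing measured here explains these readings.

With thiophen-2-yl the only five-membered ring among the compounds shown, it remains open whether furan-2-yl or thiophen-3-yl would read the same way in this assay at this carbon. On these data alone, it also remains open whether a cyclohexyl group, a longer alkyl chain or a phenyl ring bearing a carboxylic acid at this position would move the read-out beyond the scatter.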